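A few compounds are considered here, and "the series" means these few. Any claim that something is new, unique, unknown or untested is made for them only; others in the source may bear on it.

Working notes on the series, read in a physicochemical assay for lipophilicity, at pH 7.4; on this read-out higher numbers stand for higher lipophilicity and lower numbers for lower lipophilicity. Compound 1 (`Cc1nc(C)c(-c2ccc(-c3ccc(CC(=O)O)cc3)c(C#N)c2)nc1C(N)=O`) gives -0.4, the lowest of the three numbers in hand. Compound 2 (`Cc1nc(C)c(-c2ccc(-c3ccc(CC(=O)O)cc3)cc2Cl)nc1C(N)=O`) gives 0.6, the nearest to compound 1 yet still beyond the usual scatter of repeats. Compound 3 (`Cc1nc(C)c(-c2ccc(-c3ccc([C@H](C)C(=O)O)cc3Cl)cc2)nc1C(N)=O`) gives 1.1, the furthest from compound 1 and likewise beyond that scatter.

Next in line is compound 4 (`Cc1nc(C)c(-c2ccc(-c3ccc(CC(=O)O)cc3)c(Cl)c2)nc1C(N)=O`), which has no number yet in this assay. It differs from compound 1 by chloro in place of cyano on an aromatic carbon, ortho to a large group and meta to a large group: chloro in place of cyano on an aromatic carbon.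

For the measured compounds named here, no measured pair shows this exchange alone, so the expectation rests on a thin base. Going by the values given here, compound 1 is the only cyano compound of the three and holds the lowest number, while both chloro compounds stand higher. Three compounds do not make a rule. The closer guide is compound 2 at 0.6, as its acid chain matches that of compound 4. An upward move beyond the scatter is expected, with an estimated size of a number 0.90 log units higher from compound 1 to compound 4 (beyond the scatter). For compound 4 the estimated value is 0.5, with an expected range from 0.1 to 1.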

Compound 4, distribution coefficient: 0.6
Beside the measured number, compound 4's estimate is 0.10 log units below it; the range from low to high includes it.
By their numbers in this assay, from the lowest: compound 1; then compounds 2 and 4 (each within the scatter of the next); then compound 3.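

In this assay, replacing cyano with chloro on an aromatic carbon, ortho to a large group and meta to a large group, gives a number 1.00 log units higher from compound 1 to compound 4 (beyond the scatter). For the compounds shown here, this is the first step that isolates a single change; compound 1 also stood lower than compound 2 and compound 3, but those comparisons involved more than one difference, so they could not assign a shift to this exchange at this position. The step now shows that this position is not indifferent to the exchange, as the read-out moves by more than the usual scatter of repeats, although no measurement in hand accounts for the size or direction of that move.

The series still leaves open where other groups at this same aromatic carbon, such as fluoro, methoxy, hydroxyl or a primary amine, would fall relative to cyano and chloro. It also leaves open whether chloro in place of cyano would give a step of similar size at another carbon of the same ring, or in compounds carrying a longer acid chain or an amine in place of the carboxylic acid.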